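The source may report more compounds than this note shows. Statements on the series, on what has been measured and on what is new or still open speak of the compounds shown alone.

Compound 1 `O=C1c2ccccc2C(=O)N1CCOC(=S)N(C(=O)c1cccc([N+](=O)[O-])c1)c1ccc(Cl)cc1`: 18000 nM
Compound 2 `Cc1ccc(C(=O)N(C(=S)OCCN2C(=O)c3ccccc3C2=O)c2ccc(Cl)cc2)cc1`: > 100000 nM

In an ADME assay on MT4 cells (Homo sapiens) for cytotoxicity, read by MTT assay (a lower number here means that less compound is tolerated, a higher number that more compound is tolerated), compound 2 gives > 100000 nM, which is a limit of the assay and not a number. Compound 3 `O=C1c2ccccc2C(=O)N1CCOC(=S)N(C(=O)c1ccc(F)cc1F)c1ccc(Cl)cc1` carries 2,4-difluorophenyl in place of 4-methylphenyl on a carbonyl carbon.

Within the data shown here, only one measured step bears on this change, and it sits on the same carbonyl carbon: an at least 5.5-fold higher number from compound 1 to compound 2 (0.74 log units; beyond the scatter), beyond the scatter. It shows that the group at this place can move the number in this assay, but it is a single step and 2,4-difluorophenyl has not yet been measured. On the strength of an at least 5.5-fold higher number from compound 1 to compound 2 (0.74 log units; beyond the scatter), a modest move to a lower number is expected, although a result at the limit remains possible. The expected change is an at least 2.2-fold lower number from compound 2 to compound 3 (0.34 log units; beyond the scatter). Compound 3 is estimated at 45000 nM, with an expected range of 15000 nM to 100000 nM.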

Compound 3, half-maximal cytotoxic concentration: 52000 nM
The estimate for compound 3 lay 1.2-fold (0.06 log units) below the measured number, and the stated range covers the measured number.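

In this assay, replacing 3-nitrophenyl on the carbonyl carbon with 2,4-difluorophenyl gives a 2.9-fold higher number from compound 1 to compound 3 (0.46 log units; beyond the scatter), so 4-methylphenyl is no longer the only group shown to give a higher number than 3-nitrophenyl at this place. Against 4-methylphenyl, the change gives an at least 1.9-fold lower number from compound 2 to compound 3 (0.28 log units; that floor lies within the scatter), so these two groups cannot be placed in order. The value of compound 2 is a limit of the assay and not a number, which is why this step has only a floor: the limit of > 100000 nM in this assay, at which 1 of the 3 values shown sits.

As far as these compounds go, all three groups on this carbonyl carbon are six-membered aromatic rings of carbon only, so the effect of a cyclohexyl group or a pyridine ring remains open. Also open, from the compounds shown here alone, is whether 3-aminophenyl or 4-nitrophenyl would stay with 3-nitrophenyl or move towards the other two groups.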